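This account rests on a few compounds, and the source may have more. Where it says the series, first, only, none or still open, it means among the compounds named here.

Among the measured compounds shown here, compound 1 `CC(O)(CSc1ccccc1)c1nc(-c2ccc([N+](=O)[O-])c(C(F)(F)F)c2)no1` is the only compound here with a number: in a functional assay on DU-145 cells (Homo sapiens) for cytotoxicity, read by MTT assay (a lower number here means a stronger inhibitor, a higher number a weaker inhibitor), compound 1 gives 3000 nM. Compound 2 `CC(O)(CS(=O)(=O)c1ccccc1)c1nc(-c2ccccc2)no1` gives only a limit, > 100000 nM. Compound 3 `CC(O)(CS(=O)(=O)c1ccccc1)c1nc(-c2ccc(F)c(Cl)c2)no1` likewise gives only a limit, > 100000 nM. The step that the two limits leave unreadable from compound 2 to compound 3 therefore cannot be read. Compound 4 `CC(O)(CS(=O)(=O)c1ccc(F)cc1)c1nc(-c2ccc([N+](=O)[O-])c(C(F)(F)F)c2)no1` differs from compound 1 by (4-fluorophenyl)sulfonyl in place of phenylsulfanyl on a saturated chain carbon, two bonds along the chain from an aromatic carbon and an oxygen on a saturated carbon. For the measured compounds named here, no measured step covers this change; compounds 2 and 3, which both carry a sulfonyl rather than a sulfanyl linker, sit at the limit of > 100000 nM in this assay, at which 2 of the 3 values shown sit, though each also differs from compound 1 in the aromatic ring on the shared core. The expected step of a 10-fold higher number from compound 1 to compound 4 (1.00 log units; beyond the scatter) is therefore a loss of potency, with wide uncertainty. Compound 4 is estimated at 30000 nM, between 5000 nM and 150000 nM.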

Compound 4, half-maximal inhibitory concentration: > 100000 nM
Compound 4: only a limit was reported (the forecaster's own chance of this, stated with the estimate: 35%); middle value at least 3.3-fold (0.52 log units) from the limit.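

With the rest of compound 1 kept, (4-fluorophenyl)sulfonyl in place of phenylsulfanyl gives an at least 33-fold higher number from compound 1 to compound 4 (1.52 log units; beyond the scatter) in this assay, a large loss of potency from this single change. The value of compound 4 is a limit, not a measured number. Compounds 2 and 3 also differ from compound 1 in the aromatic ring on the shared core, whereas compound 4 ties the loss to this chain position alone, and the limit now covers most of the set: the limit of > 100000 nM in this assay, at which 3 of the 4 values shown sit.

The step joins two changes, the sulfonyl in place of the sulfanyl and the added fluorine, and the compounds shown do not separate them. Also open, going by these compounds, is whether an amine, a carboxylic acid or a longer chain at this carbon would keep the potency of compound 1.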